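Swapping octyl for 4-phenylphenyl at the chain end

A few compounds are considered here, and "the series" means these few. Any claim that something is new, unique, unknown or untested is made for them only; others in the source may bear on it.

Measured in a functional assay on BXPC-3 cells (Homo sapiens) for inhibition, read by XTT assay, with a stated time of 72 h; a higher number here means a weaker inhibitor, a lower number a stronger inhibitor:
- compound 1 `C=CCCCCCCCCCOC[C@@H]1CCCN1C(=O)OC(C)(C)C`: 50000 nM
- compound 2 `CCCCCCCC/C=C/CCCCCCCCOC[C@@H]1CCCN1C(=O)OC(C)(C)C`: > 100000 nM

Compound 2 gives only a limit of the assay, > 100000 nM, not a number. Compound 3 `CC(C)(C)OC(=O)N1CCC[C@H]1COCCCCCCCC/C=C/c1ccc(-c2ccccc2)cc1` has not been measured. The change in structure is 4-phenylphenyl in place of octyl on a double-bonded chain carbon bound to a double-bonded chain carbon. Among the measured compounds shown here, the one measured step is an at least 2.0-fold higher number from compound 1 to compound 2 (0.30 log units; that floor lies within the scatter); it gives only a floor and involves no ring, so it sets no size for this change. For the measured compounds named here, with compound 1 at 50000 nM as the sole numeric reading, a result in the same range is expected in this assay. The expected change is small, toward a lower number: an at least 1.4-fold lower number from compound 2 to compound 3 (0.15 log units; that floor lies within the scatter). For compound 3 the estimate is 70000 nM, with an expected range of 20000 nM to 100000 nM.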

Compound 3, half-maximal inhibitory concentration: 70000 nM
Estimate against measurement, compound 3: no gap at the digits printed, within the range that was stated.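

Putting 4-phenylphenyl in place of octyl on a double-bonded chain carbon bound to a double-bonded chain carbon gives an at least 1.4-fold lower number from compound 2 to compound 3 (0.15 log units; that floor lies within the scatter) in this assay. Compound 2 gives only a limit of the assay, > 100000 nM, not a number. This position therefore tolerates two six-membered aromatic rings of carbon only without loss of a numeric reading, but the size of the change remains a floor because of that limit: the limit of > 100000 nM in this assay, at which 1 of the 3 values shown sits.

Open, as far as these compounds go, is whether a single phenyl ring at this place would read differently from 4-phenylphenyl. Also open, from the compounds shown here alone, is whether an amine or a carboxylic acid on the chain end would move the reading beyond the scatter.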